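Double-bond geometry in the methyl ether pair

This account rests on a few compounds, and the source may have more. Where it says the series, first, only, none or still open, it means among the compounds named here.

In a functional assay on BMEC cells (Bos taurus) for antiproliferative activity (a lower number here means a stronger inhibitor, a higher number a weaker inhibitor), compound 1 (`COc1cc(/C=C\Cc2cc(O)c3ccsc3c2)cc(OC)c1OC`) gives 87 nM and compound 2 (`COc1cc(/C=C/Cc2cc(O)c3ccsc3c2)cc(OC)c1OC`) gives 38700 nM while compound 3 (`COc1cc(/C=C\Cc2cc(OC)c3ccsc3c2)cc(OC)c1OC`) gives 8100 nM and so holds the middle of the three numbers. Methyl in place of hydrogen on an oxygen on an aromatic ring accounts for a 93-fold higher number from compound 1 to compound 3 (1.97 log units; beyond the scatter) in this series.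

Compound 4 (`COc1cc(/C=C/Cc2cc(OC)c3ccsc3c2)cc(OC)c1OC`) is the partner of compound 3: the two compounds have the same atoms and bonds and differ only in configuration as drawn: 1 of 1 stereo elements differ; a double bond is drawn Z in compound 3 and E in compound 4.

Given the fact that compounds 1 and 2 differ only in the configuration as drawn the closest guide is a 440-fold higher number from compound 1 to compound 2 (2.65 log units; beyond the scatter) for the same change from Z to E. A step of that full size is not expected here: starting from compound 3 at 8100 nM it would land far above compound 2 at 38700 nM, the highest number so far. A smaller move in the same direction is therefore expected, estimated as a 4.3-fold higher number from compound 3 to compound 4 (0.64 log units; beyond the scatter) in this assay, and it may not clear the scatter by much. For compound 4 the estimated value is 35000 nM (expected range 12000 nM to 100000 nM).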

Compound 4, half-maximal inhibitory concentration: 53000 nM
Estimate against measurement, compound 4: 1.5-fold (0.18 log units) below; the measured number falls inside the stated range.
By their numbers in this assay, from the lowest: compound 1; then compound 3; then compounds 2 and 4 (each within the scatter of the next).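

The change from Z to E on the methyl ether compounds runs in the same direction in this assay as on the hydroxyl compounds, but the size differs: a 6.5-fold higher number from compound 3 to compound 4 (0.82 log units; beyond the scatter), against a 440-fold higher number from compound 1 to compound 2 (2.65 log units; beyond the scatter). Methyl in place of hydrogen on the aromatic oxygen also behaves differently on the E compounds, a 1.4-fold higher number from compound 2 to compound 4 (0.14 log units; within the scatter), so the large loss seen with this change on the Z compounds has no readable counterpart there. Within these four compounds, the effect of the methyl therefore depends on the double-bond geometry: the same change on two cores in this assay, a 93-fold higher number (1.97 log units; beyond the scatter) from compound 1 to compound 3 and a 1.4-fold higher number (0.14 log units; within the scatter) from compound 2 to compound 4, 68-fold (1.83 log units) apart, beyond the scatter of two such steps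

The compounds shown leave open whether an amine or an ethyl ether in place of the hydroxyl on the Z core would stay near compound 1 at 87 nM or move toward compound 3 at 8100 nM.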